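Orexin type 2 binding: a dimethoxybenzyl variant of compound 2

A few compounds are considered here, and "the series" means these few. Any claim that something is new, unique, unknown or untested is made for them only; others in the source may bear on it.

Measured compounds in an assay on isolated protein for displacement of a labelled ligand from Orexin receptor type 2 (Homo sapiens), read by scintillation counting, with a stated time of 60 min; a lower number here means a stronger inhibitor, a higher number a weaker inhibitor:
- compound 1, `Cc1cc(C)cc(-c2cnc(-c3cccnc3)c(C(=O)N(C)Cc3ccc4nccnc4c3)c2)c1`: 78.5 nM
- compound 2, `Cc1cc(C)cc(-c2cnc(-c3cccnc3)c(C(=O)NCc3ccc(F)c(C)c3)c2)c1`: 18 nM
- compound 3, `Cc1cc(C)cc(-c2cnc(-c3cccnc3)c(C(=O)NCc3ccc(C(F)(F)F)c(F)c3)c2)c1`: 4.1 nM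

Compound 2 stands second highest of the three numbers; its nearest neighbour is compound 1 and its furthest is compound 3, which also shares the amide part of the scaffold. Going by the values given here, the single measured step that bears on the new compound is a 4.4-fold lower number from compound 2 to compound 3 (0.64 log units; beyond the scatter), where one benzyl group was swapped for another on the same saturated chain carbon. Compound 4, `COc1ccc(CNC(=O)c2cc(-c3cc(C)cc(C)c3)cnc2-c2cccnc2)cc1OC`, differs from compound 2 by 3,4-dimethoxyphenyl in place of 4-fluoro-3-methylphenyl on a saturated chain carbon bound to an amide-type nitrogen. Among the compounds with values here, the only comparable step points toward a lower number for a fluorinated ring; a dimethoxy ring has no precedent here, so the direction is uncertain. Compound 4 is expected to show a small to modest shift, estimated at 40 nM with a range of 12 nM to 130 nM, meaning an expected step of a 2.2-fold higher number from compound 2 to compound 4 (0.35 log units; beyond the scatter).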

Compound 4, inhibition constant: 0.7 nM
For compound 4 the middle estimate is 57-fold (1.76 log units) above the measured one; measured number outside the range, below it.
By their numbers in this assay, from the lowest: compound 4; then compound 3; then compound 2; then compound 1.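

In this assay the change to 3,4-dimethoxyphenyl on a saturated chain carbon bound to an amide-type nitrogen gives a 26-fold lower number from compound 2 to compound 4 (1.41 log units; beyond the scatter) and also a 5.9-fold lower number from compound 3 to compound 4 (0.77 log units; beyond the scatter). Among compounds 2, 3 and 4, then, the lowest number belongs to the ring that carries no fluorine, so fluorine on this ring is not required for a low number. No evidence on hand accounts for this difference. From the compounds shown here alone, how a single methoxy group or a hydroxyl group on this ring would compare remains open, as does whether both methoxy groups contribute.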